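The source may hold more compounds than are shown below. What is called first, only, known or untested is meant among the compounds shown, and "the series" means these compounds.

Measured in a functional assay on SMOV2 cells (Homo sapiens) for antiproliferative activity, read by sulforhodamine B assay, with a stated time of 3 days; on this read-out higher numbers stand for weaker inhibition of growth and lower numbers for stronger inhibition of growth:
Compound 1 `CN(C)Cc1cc(F)ccc1-c1nc(-c2ccc3[nH]c(=O)oc3c2)cs1`: 10 nM
Compound 2 `NCCOCc1cc(F)ccc1-c1nc(-c2ccc3[nH]c(=O)oc3c2)cs1`: 3 nM

Of these two, compound 2 has the lower number, 3 nM. Compound 3 `COCCOCc1cc(F)ccc1-c1nc(-c2ccc3[nH]c(=O)oc3c2)cs1` changes its side chain: methoxy in place of amino on a saturated chain carbon, two bonds along the chain from an oxygen on a saturated carbon. Going by the values given here, the only measured step bearing on this is a 3.3-fold lower number from compound 1 to compound 2 (0.52 log units; beyond the scatter), which also altered the side chain. Among the compounds with values here, no measured compound lacks an amine there, so the guidance is limited. A modest step to a higher number in this assay is expected, of about the size of that one. The expected change is a 2.3-fold higher number from compound 2 to compound 3 (0.37 log units; beyond the scatter). Compound 3 is estimated at 7 nM, with an expected range of 2 nM to 25 nM.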

Compound 3, concentration for 50% growth inhibition: 2 nM
Estimate against measurement, compound 3: 3.5-fold (0.54 log units) above; the measured number falls inside the stated range.
By their numbers in this assay, from the lowest: compounds 3 and 2 (each within the scatter of the next); then compound 1.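

In this assay, methoxy in place of amino at the end of this chain gives a 1.5-fold lower number from compound 2 to compound 3 (0.18 log units; within the scatter), so here the amine can give way to an ether end without a change beyond the scatter. Compound 1 and compound 3 extend the comparison: 2-methoxyethoxy in place of dimethylamino gives a 5.0-fold lower number from compound 1 to compound 3 (0.70 log units; beyond the scatter), showing that a side chain without an amine can still read lower than compound 1. No measurement given here accounts for either step. The compounds shown leave open how a carboxylic acid or a longer chain would read at this chain end.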